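Removing the benzyl group from compound 3

The compounds below may be only part of what the source reports. "The series", "measured", "known", "first", "only" and "open" are said of these compounds alone.

Measured in a functional assay on U-937 cells (Homo sapiens) for inhibition, read by MTT assay, with a stated time of 24 h (on this read-out lower numbers stand for stronger inhibition of growth and higher numbers for weaker inhibition of growth), so far:
compound 1 `O=C1CC(c2ccc(NC(=O)c3ccc(Cl)c(C(F)(F)F)c3)cc2)=Nc2cnn(Cc3ccccc3)c2N1` gives 60 nM
compound 2 `Cc1cn(-c2cc(C(=O)Nc3cccc(C4=Nc5cnn(Cc6ccccc6)c5NC(=O)C4)c3)cc(C(F)(F)F)c2)cn1` gives > 30000 nM
compound 3 `O=C1CC(c2ccc(NC(=O)Nc3ccc(Cl)c(C(F)(F)F)c3)cc2)=Nc2cnn(Cc3ccccc3)c2N1` gives 8680 nM

The entry for compound 2 (> 30000 nM) is a limit of the assay and not a number. For the measured compounds named here, compound 3 therefore holds the higher of the two true numbers, and compound 1 is its only numeric neighbour (a 140-fold higher number from compound 1 to compound 3 (2.16 log units; beyond the scatter)).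

Next comes compound 4 `O=C1CC(c2ccc(NC(=O)Nc3ccc(Cl)c(C(F)(F)F)c3)cc2)=Nc2cn[nH]c2N1`, which has hydrogen in place of benzyl on an aromatic nitrogen. Going by the values given here, no measured step touches that nitrogen, since compounds 1, 2 and 3 all carry the benzyl. Among the compounds with values here, the one measured step sits on a carbonyl carbon, so it bears only indirectly: in compound 3 that single change moved the number a long way (a 140-fold higher number from compound 1 to compound 3 (2.16 log units; beyond the scatter)). The direction is therefore a judgement, and a moderate to large step toward a higher number is expected, with wide uncertainty. The expected change is a 2.3-fold higher number from compound 3 to compound 4 (0.36 log units; beyond the scatter), on this indirect basis. For compound 4 the estimated value is 20000 nM, within an expected range of 5000 nM to 60000 nM, and a report as a limit alone is quite possible.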

Compound 4, concentration for 50% growth inhibition: > 30000 nM
Compound 4: only a limit was reported (the forecaster's own chance of this, stated with the estimate: 50%); middle value at least 1.5-fold (0.17 log units) from the limit.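

In this assay compound 4 gives > 30000 nM, which is a limit of the assay and not a number. For the compounds shown here, this is the first reading at the aromatic nitrogen of the five-membered ring: hydrogen in place of benzyl gives an at least 3.4-fold higher number from compound 3 to compound 4 (0.53 log units; beyond the scatter), so of the two compounds carrying the (4-chloro-3-(trifluoromethyl)phenyl)amino group, only the one with benzyl on that nitrogen returns a number. The step is a lower bound, and its full size cannot be read, as compound 4 sits at the same ceiling as compound 2: the limit of > 30000 nM in this assay, at which 2 of the 4 values shown sit.

As far as these compounds go, it remains open whether hydrogen in place of benzyl would have a comparable effect on compound 1, which gives 60 nM in this assay and retains far more room for a loss to be read as a number. Also open is how much of the benzyl is needed, since the compounds shown carry only benzyl or hydrogen on that nitrogen, and a methyl group or a longer chain such as phenethyl would separate the presence of any carbon substituent from that of the aromatic ring.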